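The compounds below may be only part of what the source reports. "The series", "measured", "known", "first", "only" and "open" are said of these compounds alone.

Compound 1 `COc1cc(OC)c2cc(-c3ccc(OCc4ccccc4)cc3)c(O)nc2c1` and compound 2 `COc1ccc(-c2cc3c(OC)cc(OC)cc3n(C)c2=O)cc1` share a core that carries two methoxy groups, and each bears a methoxy- or benzyloxy-substituted phenyl ring. In a functional assay on J82 cells (Homo sapiens) for cytotoxicity, read by colorimetric assay and MTT assay (a lower number here means a stronger inhibitor, a higher number a weaker inhibitor), compound 1 gives 10000 nM, and in this assay compound 2 gives 10000 nM; the two values stand level at the digits shown, with no difference beyond the usual scatter between them.

Compound 3 `COc1ccc(-c2cc3c(OC)cc(OC)cc3n(CC#N)c2=O)cc1` has not yet been measured in this assay. It differs from compound 2 in one place: cyano in place of hydrogen on a saturated chain carbon bound to an aromatic nitrogen. Read one bond further out, the methyl on the aromatic nitrogen becomes a cyanomethyl. For the measured compounds named here, no measured pair shows what this kind of change does here, so the expected step from compound 2 to compound 3 is estimated as no change at the digits printed from compound 2 to compound 3 (within the scatter), that is, none beyond the scatter. On that basis compound 3 is expected to give about 10000 nM, within a range from 4000 nM to 25000 nM.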

Compound 3, half-maximal inhibitory concentration: 10000 nM
For compound 3 middle estimate and measured number coincide at the digits printed; low and high end bracket the measured number.
By their numbers in this assay, from the lowest: compounds 1, 2 and 3 (each within the scatter of the next).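

For the compounds shown here, the swap of methyl for cyanomethyl on the aromatic nitrogen gives no change at the digits printed from compound 2 to compound 3 (within the scatter) in this assay and is the first change in a single place that can be read. It shows that adding a cyano group to this saturated chain carbon leaves the cell result unmoved, so this one substitution offers no route to a lower number. Nothing measured here gives a reason for this result.

From the compounds shown here alone, whether a different group at this position, such as an amine, a carboxylic acid or a longer chain, would shift the value in this assay remains open. Also open, going by these compounds, is whether a change elsewhere on the shared core or on its methoxy-bearing phenyl ring would move the number at all.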